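The source may report more compounds than this note shows. Statements on the series, on what has been measured and on what is new or still open speak of the compounds shown alone.

Of the compounds shown here, two have been measured in an assay for positive allosteric modulation of metabotropic glutamate receptor 2 (Rattus norvegicus); a lower number here means that less compound is needed, a higher number that more compound is needed for the effect. Compound 1, `Cc1c(OC[C@H](C)COc2ccc(F)c(C(=O)O)c2)ccc(C(=O)CC(C)(C)C)c1O`, gives in this assay 294 nM. Compound 2, `Cc1cc(C(=O)O)ccc1OC[C@H](C)COc1ccc(C(=O)CC(C)(C)C)c(O)c1C`, gives in this assay 446 nM. Compound 2 has the higher of the two numbers, but its gap to compound 1 lies within the usual scatter of the measurement, so the two results cannot be told apart.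

Compound 3, `Cc1c(OC[C@@H](C)COc2ccc(C(=O)O)c(Cl)c2)ccc(C(=O)CC(C)(C)C)c1O`, has not yet been measured. It differs from compound 2 in one place: 4-carboxy-3-chlorophenyl in place of 4-carboxy-2-methylphenyl on an oxygen on a saturated carbon. Compound 1 already shows that moving the carboxylic acid and exchanging the small ring substituent leaves the number within the scatter, and nothing in the data points to a larger effect for a chlorine in the place of a methyl group. The step from compound 2 to compound 3 is therefore expected to stay within the scatter, a 1.3-fold lower number from compound 2 to compound 3 (0.11 log units; within the scatter). Compound 3 is estimated to give 350 nM, with a range from 150 nM to 800 nM.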

Compound 3, half-maximal effective concentration: 50 nM
Compound 3: middle estimate off by 7.0-fold (0.85 log units), on the high side; measured number below the stated range.
By their numbers in this assay, from the lowest: compound 3; then compounds 1 and 2 (each within the scatter of the next).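

In this assay, for the compounds shown here, the exchange of 4-carboxy-2-methylphenyl for 4-carboxy-3-chlorophenyl on an oxygen on a saturated carbon gives an 8.9-fold lower number from compound 2 to compound 3 (0.95 log units; beyond the scatter) and is the only step here that lies beyond the scatter. This shows that the number responds to the make-up of this ring, which compounds 1 and 2 alone could not show, since their values lie within the scatter of each other. Nothing at hand explains why the number falls.

The step changes two things at once, the small group (chlorine for methyl) and its ring position, so the compounds shown leave open which of the two matters. As far as these compounds go, a 4-carboxy-3-methylphenyl or a 4-carboxy-2-chlorophenyl group would separate them, and whether a 4-carboxy-3-fluorophenyl group behaves like the chlorine compound also remains open.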